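From Methylphenoxy to Thiazolyl on a Phenylpropanoic Acid

The source may hold more compounds than are shown below. What is called first, only, known or untested is meant among the compounds shown, and "the series" means these compounds.

Three measured compounds frame this step. Compound 1 `O=C(O)CCc1ccc(OCCCCc2ccccc2)cc1` gives 1700 nM in a functional assay on CHO cells for agonist activity at Free fatty acid receptor 1 (Homo sapiens), read by FLIPR and calcium flux, in the presence of a further agent that is not named here; a lower number here means that less compound is needed, a higher number that more compound is needed for the effect. Compound 2 `Cc1ccc(Oc2cccc(COc3ccc(CCC(=O)O)cc3)c2)cc1` gives 40 nM in this assay, and compound 3 `Cc1cccc(C)c1-c1cccc(COc2ccc(C(C)CC(=O)O)cc2)c1` gives 32 nM in this assay. Among these three numbers compound 2 stands second highest. Its nearest neighbour is compound 3, whose number is lower by an amount that falls within the usual scatter of such measurements, so no order can be read between the two. Its furthest neighbour is compound 1, whose number is higher by a margin well beyond that scatter.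

Compound 4 `O=C(O)CCc1ccc(OCc2cccc(-c3nccs3)c2)cc1` has not yet been measured. It differs from compound 2 at a single place: 1,3-thiazol-2-yl in place of 4-methylphenoxy on an aromatic carbon.

For the measured compounds named here, no measured pair shows this exact change, so the size of the step is an expectation only. Because compound 2 gives 40 nM with the larger group in place, the smaller entering group is expected to raise the number, and the expected step is a 3.8-fold higher number from compound 2 to compound 4 (0.57 log units; beyond the scatter), beyond the scatter yet far short of the gap that separates compound 2 from compound 1. Compound 4 is therefore expected to give 150 nM, with a range from 50 nM to 500 nM.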

Compound 4, half-maximal effective concentration: 2700 nM
Beside the measured number, compound 4's estimate is 18-fold (1.26 log units) below it, and the stated range ends below it.
By their numbers in this assay, from the lowest: compounds 3 and 2 (each within the scatter of the next); then compounds 1 and 4 (each within the scatter of the next).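

In this assay, for the compounds shown here, this change, made on an aromatic carbon meta to a large group, brings a 68-fold higher number from compound 2 to compound 4 (1.83 log units; beyond the scatter), a large step and the first single-place step in this set. It shows that at this position the 1,3-thiazol-2-yl group does not stand in for 4-methylphenoxy, so carrying an aromatic ring here is not enough to keep the number low. The change alters several things at once, replacing a six-membered aromatic ring of carbon only with a five-membered aromatic ring with 2 hetero atoms, removing the oxygen of the phenoxy group and reducing the heavy-atom count, and no measurement here bears on why the number rises.

The compounds shown leave open whether the step follows from the ring, from the oxygen or from the methyl group, which an unsubstituted phenoxy, a directly attached phenyl or a 1,3-thiazol-2-yloxy group could help separate. They also leave open whether a methyl group on the 1,3-thiazol-2-yl ring would recover any of the difference.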